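The source may hold more compounds than are shown below. What is called first, only, known or untested is meant among the compounds shown, and "the series" means these compounds.

Compound 1 (`COc1ccc(S(=O)(=O)Nc2ccccc2CCc2ccc(C(=O)Nc3ccccc3N)cc2)cc1`) is the reference point for this step. Among the measured compounds shown here, in a functional assay on KB cells (Homo sapiens) for antiproliferative activity, read by sulforhodamine B assay, with a stated time of 48 h (a lower number here means a stronger inhibitor of growth, a higher number a weaker inhibitor of growth), compound 1 gives 23 nM, the only exact number so far. Compound 2 (`COc1ccc(S(=O)(=O)Nc2ccccc2CCc2ccc(C(=O)NO)cc2)cc1`) shows > 10000 nM, which is a limit of the assay and not a number. For the measured compounds named here, the one measured step, an at least 430-fold higher number from compound 1 to compound 2 (2.63 log units; beyond the scatter), is large and puts hydroxy in place of 2-aminophenyl on an amide-type nitrogen. That change lies elsewhere in the molecule, so it sets no size for the change considered here.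

Compound 3 (`Nc1ccccc1NC(=O)c1ccc(CCc2ccccc2NS(=O)(=O)c2ccccc2)cc1`) keeps that 2-aminophenyl group and has hydrogen in place of methoxy on an aromatic carbon, turning 4-methoxyphenyl into phenyl: hydrogen in place of methoxy on an aromatic carbon. Going by the values given here, no measured step covers this swap, so no shift beyond the scatter in this assay is expected, and no direction is favoured. The expected step is a 1.3-fold higher number from compound 1 to compound 3 (0.12 log units; within the scatter). For compound 3 the estimated value is 30 nM, with an expected range from 10 nM to 100 nM.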

Compound 3, concentration for 50% growth inhibition: 456 nM
Compound 3: the middle estimate sits 15-fold (1.18 log units) below what was measured; the measured number lies above the stated range.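

Taking the methoxy group off the 4-methoxyphenyl ring gives a 20-fold higher number from compound 1 to compound 3 (1.30 log units; beyond the scatter) in this assay and so shows that this place on the molecule is not a bystander. The earlier step concerned the other end of the structure, the 2-aminophenyl group, while this one shows that a change as small as methoxy to hydrogen, with everything else in compound 1 kept, also moves the number well beyond the scatter. Growth inhibition is weakened but not lost, since compound 3 still gives an exact number and not a limit of the assay.

Open, as far as these compounds go, is whether a hydroxy group, a methyl group, a chlorine atom or an ethoxy group on this carbon would bring the number back towards compound 1 or leave it nearer compound 3. Nothing measured here bears on why methoxy and hydrogen differ so much at this place.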